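From Compound 1 to Compound 4: An Expected Fall

A few compounds are considered here, and "the series" means these few. Any claim that something is new, unique, unknown or untested is made for them only; others in the source may bear on it.

Measured in an ADME assay on microsomes from liver (Rattus norvegicus) for metabolic stability, using NADPH, with a stated time of 10 min (on this read-out higher numbers stand for a more stable compound and lower numbers for a less stable compound), so far
compound 1 `CCCCc1nc(=O)c(S(=O)(=O)c2ccc(-n3ccccc3=O)cc2)c(O)n1-c1c(OC)cccc1OC` gives 83%
compound 2 `CCCCc1[nH]c(=O)c(S(=O)(=O)c2ccc(-c3ccc(F)cc3)cc2)c(O)c1-c1c(OC)cccc1OC` gives "not determined" (no result reported)
compound 3 `COc1cccc(OC)c1-n1c(CCC(C)C)nc(=O)c(S(=O)(=O)c2ccc(-c3ccc(F)nc3)cc2)c1O` gives 1%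

Compound 1 holds the higher of the two numbers, lying beyond the scatter above compound 3, while compound 2 has no number. Compound 4 `CCCCc1nc(=O)c(S(=O)(=O)c2ccc(C3CC3)cc2)c(O)n1-c1c(OC)cccc1OC` differs from compound 1 in one place, where cyclopropyl stands on an aromatic carbon, para to a large group (a group of 3 heavy atoms (3 carbon; one three-membered non-aromatic ring of carbon only) in place of a group of 7 heavy atoms (5 carbon, 1 nitrogen, 1 oxygen; one six-membered aromatic ring with 1 hetero atom), on an aromatic carbon). Among the measured compounds shown here, no measured pair differing in one place gives a guide in this assay, so the size of the step remains uncertain. A fall beyond the scatter is expected. Compound 3 shows how low a compound of this kind can go (1%). The expected change is a number 43 percentage points lower from compound 1 to compound 4 (beyond the scatter) as an estimate. For compound 4 the estimated value is 40%, within a range from 8% to 78% for now.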

Compound 4, percent of the compound remaining: 59%
The estimate for compound 4 lay 19 percentage points below the measured number; the measured number falls inside the stated range.
By their numbers in this assay, from the lowest: compound 3; then compound 4; then compound 1.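

In this assay, the aromatic carbon para to a large group is now shown to bear on the read-out: cyclopropyl in place of the six-membered aromatic ring with 1 hetero atom gives a number 24 percentage points lower from compound 1 to compound 4 (beyond the scatter) while compound 4 still reads 59% on this scale. The step alone cannot separate the smaller group from the loss of its hydrogen-bond acceptors. No measurement shown here accounts for this step.

Going by these compounds, whether an amine, a carboxylic acid or a longer chain on this aromatic carbon would stand nearer compound 1 or compound 4 remains open.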